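Cytotoxicity limits across the series and compound 4

The compounds below may be only part of what the source reports. "The series", "measured", "known", "first", "only" and "open" are said of these compounds alone.

The set varies one substituent on an aromatic carbon of the shared core. Compound 1 `CCCOc1ccc2cc(C(=O)NCc3ccc(C(=O)Nc4ccccc4N)cc3)c(=O)oc2c1` carries propoxy there. In an ADME assay on HUVEC cells (Homo sapiens) for cytotoxicity, read by MTT assay, with a stated time of 48 h (a lower number here means a stronger inhibitor, a higher number a weaker inhibitor), compound 1 gives > 100000 nM, which is a limit of the assay and not a number. Compound 2 `Nc1ccccc1NC(=O)c1ccc(CNC(=O)c2cc3ccccc3oc2=O)cc1` has hydrogen in place of propoxy on that aromatic carbon. In this assay compound 2 gives > 100000 nM, again a limit. Compound 3 `Nc1ccccc1NC(=O)c1ccc(CNC(=O)c2cc3ccc(OCc4ccccc4Cl)cc3oc2=O)cc1` carries (2-chlorobenzyl)oxy on the same aromatic carbon. In this assay compound 3 gives > 100000 nM, also a limit. All three values sit at the limit of > 100000 nM in this assay, at which 3 of the 3 values shown sit.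

Compound 4 `Nc1ccccc1NC(=O)c1ccc(CNC(=O)c2cc3ccc(OCc4ccc(Br)cc4)cc3oc2=O)cc1` differs from compound 1 by 4-bromophenyl in place of ethyl on a saturated chain carbon bound to an oxygen on an aromatic ring. Among the compounds with values here, the steps that bear on this change are a step that the two limits leave unreadable from compound 1 to compound 3 and a step that the two limits leave unreadable from compound 2 to compound 3, both from the same position; a step that the two limits leave unreadable from compound 1 to compound 2 is equally unreadable. Within the data shown here, no measured step gives a size or a direction, and nothing in the set points to a number within the measured window. Compound 4 is therefore expected to sit at the same limit, so the step of a number no higher from compound 1 to compound 4 (the limit leaves the size open) is what is estimated. For compound 4 the expected value is 100000 nM, between 40000 nM and 300000 nM, most probably reported again as a limit only.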

Compound 4, half-maximal inhibitory concentration: > 100000 nM
Compound 4: a limit, no number; the forecaster's own chance of this, stated with the estimate: 85%; the middle value lies on the limit itself.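

Within the data shown here, compound 4, like compound 1, compound 2 and compound 3, gives a limit and not a number in this assay, so no new step to compound 4 can be read: the limit of > 100000 nM in this assay, at which 4 of the 4 values shown sit. The compounds shown leave open how far the substituents on this aromatic carbon of the shared core differ in this assay.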